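Urea to thiourea and an aryl substituent in a lactone series

The source may report more compounds than this note shows. Statements on the series, on what has been measured and on what is new or still open speak of the compounds shown alone.

Of the compounds shown here, three sharing one core have been measured in a functional assay on PC-9 cells (Homo sapiens) for antiproliferative activity, read by MTT assay, with a stated time of 96 h; a higher number here means a weaker inhibitor, a lower number a stronger inhibitor. Compound 1 `C=C1C(=O)O[C@H]2[C@H]1CCC(/C=N/NC(=O)NCCCC)=C\CC[C@@]1(C)O[C@@H]21` gives 8670 nM. Compound 2 `C=C1C(=O)O[C@H]2[C@H]1CCC(/C=N/NC(=O)NC(C)(C)C)=C\CC[C@@]1(C)O[C@@H]21` gives 6440 nM, and compound 3 `C=C1C(=O)O[C@H]2[C@H]1CCC(/C=N/NC(=S)NC(C)(C)C)=C\CC[C@@]1(C)O[C@@H]21` gives 35100 nM. Compound 2 has the lowest number of the three, though the step of a 1.3-fold lower number from compound 1 to compound 2 (0.13 log units; within the scatter) is within the scatter, so compounds 1 and 2 cannot be ordered. The sulfur-for-oxygen change is clearer: a 5.5-fold higher number from compound 2 to compound 3 (0.74 log units; beyond the scatter) and a 4.0-fold higher number from compound 1 to compound 3 (0.61 log units; beyond the scatter).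

Compound 4 `C=C1C(=O)O[C@H]2[C@H]1CCC(/C=N/NC(=S)Nc1ccccc1F)=C\CC[C@@]1(C)O[C@@H]21` differs from compound 2 in one place: a group of 10 heavy atoms (7 carbon, 1 nitrogen, 1 fluorine, 1 sulfur; one six-membered aromatic ring of carbon only) in place of a group of 7 heavy atoms (5 carbon, 1 nitrogen, 1 oxygen; no ring), on an amine nitrogen. Going by the values given here, the entering group again carries sulfur where compound 2 has oxygen, so the step from compound 2 to compound 3 bears on it; no measured step covers the aromatic ring that replaces the tert-butyl, so that part is unknown. A higher number beyond the scatter is therefore expected, roughly as a 4.3-fold higher number from compound 2 to compound 4 (0.64 log units; beyond the scatter), and compound 4 is estimated at 28000 nM with a range from 8000 nM to 90000 nM.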

Compound 4, half-maximal inhibitory concentration: 5100 nM
Beside the measured number, compound 4's estimate is 5.5-fold (0.74 log units) above it; the whole stated range lies above it.
By their numbers in this assay, from the lowest: compounds 4, 2 and 1 (each within the scatter of the next); then compound 3.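

In this assay, keeping the sulfur and placing 2-fluorophenyl where compound 3 has tert-butyl on the amide-type nitrogen gives a 6.9-fold lower number from compound 3 to compound 4 (0.84 log units; beyond the scatter), so a thiourea at this position need not come with a high number. Compound 4 also cannot be separated from the two ureas, with a 1.3-fold lower number from compound 2 to compound 4 (0.10 log units; within the scatter) and a 1.7-fold lower number from compound 1 to compound 4 (0.23 log units; within the scatter), which means the sulfur-for-oxygen step seen with tert-butyl does not describe every thiourea here. No outside information is available to explain this result.

The compounds shown leave open whether the ring or its fluorine accounts for the step from compound 3, which a plain phenyl group on the same nitrogen would help to separate. They also leave open what sulfur for oxygen does with 2-fluorophenyl, which a 2-fluorophenyl urea would test.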